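The source may report more compounds than this note shows. Statements on the series, on what has been measured and on what is new or still open speak of the compounds shown alone.

Compound 1 `CC#CC(CC(=O)O)c1ccc(OCc2ccc3nc(-c4ccc(C(C)C)cc4)cn3c2)cc1` and compound 2 `CC#CC(CC(=O)O)c1ccc(OCc2ccn3cc(-c4ccc(F)cc4F)nc3c2)cc1` share a common core and differ in the group attached to it. In an assay on isolated protein for agonist activity at Free fatty acid receptor 1 (Homo sapiens) (on this read-out lower numbers stand for an effect already at smaller amounts and higher numbers for an effect only at larger amounts of compound), compound 1 gives 528 nM, the lower of the two numbers, while compound 2 gives 792 nM; the two lie within the usual scatter of each other, so no order between them can be claimed. Compound 3 `CC#CC(CC(=O)O)c1ccc(OCc2ccc3nc(-c4ccc(C)cc4)cn3c2)cc1` has not yet been measured. It differs from compound 1 by methyl in place of isopropyl on an aromatic carbon. Going by the values given here, no measured pair shows this kind of change, so the size of the step can only be guessed; the expectation is a modest shift toward a higher number in this assay, possibly not beyond the scatter. The estimated step is a 1.7-fold higher number from compound 1 to compound 3 (0.23 log units; within the scatter). Compound 3 is estimated at 900 nM, with an expected range from 300 nM to 2700 nM.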

Compound 3, half-maximal effective concentration: 507 nM
Compound 3: middle estimate off by 1.8-fold (0.25 log units), on the high side; low and high end bracket the measured number.
By their numbers in this assay, from the lowest: compounds 3, 1 and 2 (each within the scatter of the next).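

Going by these compounds alone, compound 1 and compound 3 are the first pair here that differ in one place only, so the change from 4-isopropylphenyl to 4-methylphenyl can be read directly: in this assay it amounts to a 1.0-fold lower number from compound 1 to compound 3 (0.02 log units; within the scatter). Methyl, with 1 heavy atom against 3 for isopropyl, therefore gives a number that cannot be told apart from that of compound 1, so at this place, para to a large group, the extra carbons of isopropyl show no measurable effect on this read-out. No available data explain this result. 

From the compounds shown here alone, it remains open whether this tolerance extends to a plain hydrogen, a longer chain such as tert-butyl or hexyl, or an amine at this place. A carboxylic acid there would test a group of a quite different kind.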